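Swapping Methoxycarbonyl for Methyl in Compound 3

The source may report more compounds than this note shows. Statements on the series, on what has been measured and on what is new or still open speak of the compounds shown alone.

In a functional assay on SK-OV-3 cells (Homo sapiens) for inhibition, read by CCK-8 assay, with a stated time of 70 h (on this read-out higher numbers stand for weaker inhibition and lower numbers for stronger inhibition), compound 1 `COc1ccc(OCCOCCNC2CCCC2)cc1` gives 99100 nM, compound 2 `Nc1ccc(COc2ccc(OCCOCCNC3CCCC3)cc2)cc1` gives 31700 nM, and compound 3 `COC(=O)c1ccc(COc2ccc(OCCOCCNC3CCCC3)cc2)cc1` gives 6990 nM, the lowest of the three numbers. Compound 4 `Cc1ccc(COc2ccc(OCCOCCNC3CCCC3)cc2)cc1` has methyl in place of methoxycarbonyl on an aromatic carbon, para to a large group: methyl in place of methoxycarbonyl on an aromatic carbon. Among the measured compounds shown here, three measured steps bear on this change. The large one shows a 14-fold lower number from compound 1 to compound 3 (1.15 log units; beyond the scatter), and a modest one shows a 3.1-fold lower number from compound 1 to compound 2 (0.50 log units; beyond the scatter). The closest comparison, also modest, changes the same aromatic position and shows a 4.5-fold lower number from compound 2 to compound 3 (0.66 log units; beyond the scatter). For the measured compounds named here, no methyl analogue has been measured, so a small rise is expected, giving an expected 2.1-fold higher number from compound 3 to compound 4 (0.33 log units; beyond the scatter). For compound 4 the estimated value is 15000 nM, with a range of 5000 nM to 40000 nM.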

Compound 4, half-maximal inhibitory concentration: 17200 nM
The estimate for compound 4 lay 1.1-fold (0.06 log units) below the measured number; the measured number falls inside the stated range.
By their numbers in this assay, from the lowest: compound 3; then compounds 4 and 2 (each within the scatter of the next); then compound 1.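

Replacing methoxycarbonyl with methyl gives back part of the gain at this aromatic position (a 2.5-fold higher number from compound 3 to compound 4 (0.39 log units; beyond the scatter)), while the 4-methylphenyl group in place of hydrogen still retains a clear effect (a 5.8-fold lower number from compound 1 to compound 4 (0.76 log units; beyond the scatter)). Methyl and amino at this position are not told apart (a 1.8-fold lower number from compound 2 to compound 4 (0.27 log units; within the scatter)), a step within the scatter, so among these three groups only methoxycarbonyl stands out. No measurement shown accounts for this difference. As far as these compounds go, whether a carboxylic acid, a primary amide or a longer ester at this position would match compound 3 remains open.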